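A few compounds are considered here, and "the series" means these few. Any claim that something is new, unique, unknown or untested is made for them only; others in the source may bear on it.

Three compounds that share one core and differ in the group on the carbonyl carbon have been measured so far in a functional assay on MDA-MB-231 cells (Homo sapiens) for antiproliferative activity, read by spectrophotometry and resazurin assay, with a stated time of 72 h; on this read-out lower numbers stand for stronger inhibition and higher numbers for weaker inhibition. There compound 1 (`CC(C)CC(=O)CC1Oc2cc(O)ccc2C=C1c1ccc(O)cc1`) gives 67000 nM while compound 2 (`O=C(CC1Oc2cc(O)ccc2C=C1c1ccc(O)cc1)c1ccccc1`) gives 88000 nM and compound 3 (`Cc1ccc(C(=O)CC2Oc3cc(O)ccc3C=C2c2ccc(O)cc2)cc1`) gives 55000 nM as its value. Compound 3 cannot be separated from the other two, since both of its steps stay within the scatter (a 1.2-fold lower number from compound 1 to compound 3 (0.09 log units; within the scatter)) (a 1.6-fold lower number from compound 2 to compound 3 (0.20 log units; within the scatter)). Compound 4 (`O=C(CC1Oc2cc(O)ccc2C=C1c1ccc(O)cc1)c1ccc(Cl)cc1`) differs from compound 3 in one place (chloro in place of methyl on an aromatic carbon) with chloro in place of methyl on an aromatic carbon, para to a large group. The measured step closest to this change concerns the same aromatic carbon, with methyl in place of hydrogen (a 1.6-fold lower number from compound 2 to compound 3 (0.20 log units; within the scatter)) and it stays within the scatter. Exchanging the whole group on the carbonyl carbon also stayed within the scatter (a 1.3-fold higher number from compound 1 to compound 2 (0.12 log units; within the scatter)). Going by the values given here, no measured compound carries chloro, so the expectation rests on these three values alone. No shift beyond the scatter is expected in this assay and no firm direction can be given. The estimated step is small (a 1.1-fold higher number from compound 3 to compound 4 (0.04 log units; within the scatter)). For compound 4 the estimated value is 60000 nM with an expected range from 30000 nM to 110000 nM around it.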

Compound 4, half-maximal inhibitory concentration: 151000 nM
Compound 4: middle estimate off by 2.5-fold (0.40 log units), on the low side, and the stated range ends below it.
By their numbers in this assay, from the lowest: compounds 3, 1, 2 and 4 (each within the scatter of the next, the first and the last beyond it).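

Going by these compounds alone, at the aromatic carbon para to a large group, in this assay, exchanging methyl for chloro gave a step that passes the scatter (a 2.7-fold higher number from compound 3 to compound 4 (0.44 log units; beyond the scatter)), whereas all the steps among the earlier compounds had stayed within it, so the identity of the group on this carbon can register in this assay. The effect is limited: chloro in place of hydrogen stays within the scatter (a 1.7-fold higher number from compound 2 to compound 4 (0.23 log units; within the scatter)), so at this carbon only the methyl and chloro pair separates, while 4-chlorophenyl in place of isobutyl on the carbonyl carbon passes the scatter (a 2.3-fold higher number from compound 1 to compound 4 (0.35 log units; beyond the scatter)), which neither phenyl nor 4-methylphenyl in that exchange had done. Nothing available here offers an explanation for these steps.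

With a single chloro and a single methyl at this carbon, the compounds shown cannot tell whether the separation extends to other groups, such as a methoxy, a fluoro or an amine. They also leave open whether the same exchange would give a comparable step on a core with either of its hydroxyl groups replaced.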